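Methoxy on the cyclobutane ring: a small shift expected

A few compounds are considered here, and "the series" means these few. Any claim that something is new, unique, unknown or untested is made for them only; others in the source may bear on it.

Compound 1 `CCn1c(-c2cnc(C)nc2)nc2c(N[C@H]3CCN(C(=O)[C@H]4C[C@@H](OC)C4)C3)ncnc21` gives 2 L/kg in an ADME assay (Canis lupus familiaris, strain Beagle) for pharmacokinetics; a higher number here means that more of the compound sits outside the plasma, a lower number that more of the compound stays in the plasma. Compound 2 `CCn1c(-c2cnc(C)nc2)nc2c(O[C@H]3CCN(C(=O)C4CCC4)C3)ncnc21` gives 1.4 L/kg. Compound 3 `CCn1c(-c2cnc(C)nc2)nc2c(N[C@H]3CCN(C(=O)C4CCC4)C3)ncnc21` gives 2.3 L/kg.

Compound 4 `CCn1c(-c2cnc(C)nc2)nc2c(O[C@H]3CCN(C(=O)[C@H]4C[C@@H](OC)C4)C3)ncnc21` has not been measured. It differs from compound 2 by methoxy in place of hydrogen on a saturated ring carbon. The same change, in the same place, has already been made once, from compound 3 to compound 1: methoxy in place of hydrogen on a saturated ring carbon. That step gave a 1.2-fold lower number from compound 3 to compound 1 (0.06 log units; within the scatter). The difference between the two cores of compound 2 and compound 3 is not broken down here, and their two values sit within the scatter of each other.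

Because the earlier step of a 1.2-fold lower number from compound 3 to compound 1 (0.06 log units; within the scatter) stayed within the scatter, the step from compound 2 to compound 4 is expected to be of similar size, a 1.2-fold lower number from compound 2 to compound 4 (0.07 log units; within the scatter). Compound 4 is therefore estimated at 1.2 L/kg, likely between 0.7 L/kg and 2 L/kg.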

Compound 4, volume of distribution: 0.9 L/kg
Compound 4: middle estimate off by 1.3-fold (0.12 log units), on the high side; low and high end bracket the measured number.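

In this assay, going from cyclobutyl to 3-methoxycyclobutyl gives a 1.6-fold lower number from compound 2 to compound 4 (0.19 log units; within the scatter) and so stays as small as the earlier step, and the two steps agree: the same change on two cores in this assay, a 1.2-fold lower number (0.06 log units; within the scatter) from compound 3 to compound 1 and a 1.6-fold lower number (0.19 log units; within the scatter) from compound 2 to compound 4, 1.4-fold (0.13 log units) apart, within the scatter of two such steps. On these two cores, then, the methoxy change carries over with no detectable difference, and neither step can be told apart from the noise of repeated measurements. This does not show that methoxy really lowers the number, and two pairs cannot show that the change would act the same way on other cores.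

The compounds shown leave open whether another group in the same place on the ring, such as an amine or a carboxylic acid, would shift the volume of distribution further than methoxy. They also leave open how a longer chain there, such as ethoxy, would behave.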